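This account rests on a few compounds, and the source may have more. Where it says the series, first, only, none or still open, it means among the compounds named here.

Measured in a functional assay on PC-3 cells (Homo sapiens) for cytotoxicity, read by MTT assay, with a stated time of 72 h; a lower number here means a stronger inhibitor, a higher number a weaker inhibitor:
- Compound 1 `CNC(=O)c1cc(Oc2ccc(C(=O)/C=C/c3cccc(Br)c3)cc2)ccn1`: 3400 nM
- Compound 2 `CNC(=O)c1cc(Oc2ccc(C(=O)/C=C/c3ccc(Cl)c(Cl)c3)cc2)ccn1`: 8260 nM

Of these two, compound 2 has the higher number, which makes it the weaker inhibitor, and compound 1 is its nearest neighbour. Compound 3 `CNC(=O)c1cc(Oc2ccc(C(=O)/C=C/c3ccc(Br)cc3)cc2)ccn1` has not yet been measured. It differs from compound 2 in one place: 4-bromophenyl in place of 3,4-dichlorophenyl on a double-bonded chain carbon bound to a double-bonded chain carbon.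

Among the measured compounds shown here, only one measured step bears on this change: a 2.4-fold higher number from compound 1 to compound 2 (0.39 log units; beyond the scatter). That modest step replaced 3-bromophenyl with 3,4-dichlorophenyl, so compound 3 reverses the exchange in part, restoring a bromophenyl group. However, no compound with 4-bromophenyl has been measured, so the guide is loose. A modest drop in this assay is therefore expected, of about the same size as that step or smaller.

The expected change is a 1.8-fold lower number from compound 2 to compound 3 (0.26 log units; within the scatter). For compound 3 the estimated value is 4500 nM, with an expected range from 1800 nM to 11000 nM.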

Compound 3, half-maximal inhibitory concentration: 18500 nM
Estimate against measurement, compound 3: 4.1-fold (0.61 log units) below; measured number above the stated range.
By their numbers in this assay, from the lowest: compound 1; then compound 2; then compound 3.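

The two bromophenyl groups are not interchangeable at this place on the chain: in this assay, 4-bromophenyl in place of 3-bromophenyl gives a 5.4-fold higher number from compound 1 to compound 3 (0.74 log units; beyond the scatter), the largest step among these compounds. The 3,4-dichlorophenyl group also ranks ahead of 4-bromophenyl, with a 2.2-fold higher number from compound 2 to compound 3 (0.35 log units; beyond the scatter), so the order of numbers, from lowest to highest, is 3-bromophenyl, 3,4-dichlorophenyl, 4-bromophenyl, and each step in it lies beyond the scatter. Nothing measured here explains this order.

Among the compounds shown here, with only three halogen-bearing rings, it remains open whether the bromine or the chlorine atoms themselves drive these differences, or only where they sit on the ring. Going by these compounds, it is also open how a phenyl ring carrying an amine or a carboxylic acid would behave at this place.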